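An Isopropoxy Group in Place of a Methyl Group

A few compounds are considered here, and "the series" means these few. Any claim that something is new, unique, unknown or untested is made for them only; others in the source may bear on it.

Three compounds share one core. Compound 1 `Cc1ccc2oc(/C=C/[S+](C)[O-])cc(=O)c2c1`, compound 2 `Cc1c(/C=C/[S+](C)[O-])oc2ccccc2c1=O` and compound 3 `C[S+]([O-])/C=C/c1oc2ccccc2c(=O)c1Cc1ccccc1` were tested in a functional assay on DLD-1 cells (Homo sapiens) for cytotoxicity, with a stated time of 48 h; on this read-out higher numbers stand for weaker inhibition and lower numbers for stronger inhibition. There compound 1 gives 7000 nM, compound 2 gives 7200 nM and compound 3 gives 5100 nM. Compound 1 has the second highest of the three numbers, but all three lie within the scatter of one another. Within the data shown here, the only measured single change is a 1.4-fold lower number from compound 2 to compound 3 (0.15 log units; within the scatter). Compound 4 `CC(C)Oc1ccc2oc(/C=C/[S+](C)[O-])cc(=O)c2c1` differs from compound 1 in one place: isopropoxy in place of methyl on an aromatic carbon. Among the measured compounds shown here, no measured step involves this position or this kind of change, and the one measured step was itself within the scatter, so no step beyond the scatter is expected in this assay in either direction. Compound 4 is therefore expected to give about 7000 nM, between 2500 nM and 20000 nM, which amounts to an expected step of no change at the digits printed from compound 1 to compound 4 (within the scatter).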

Compound 4, half-maximal inhibitory concentration: 8000 nM
For compound 4 the middle estimate is 1.1-fold (0.06 log units) below the measured one; the range from low to high includes it.
By their numbers in this assay, from the lowest: compounds 3, 1, 2 and 4 (each within the scatter of the next).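

In this assay, isopropoxy in place of methyl on this aromatic carbon gives a 1.1-fold higher number from compound 1 to compound 4 (0.06 log units; within the scatter) and so stays within the scatter. Among these compounds, this position, which no earlier step touched, therefore accepts a group with more heavy atoms and a hydrogen-bond acceptor without a clear shift in the number. Nothing shown gives a reason for this result. From the compounds shown here alone, whether an amine or a carboxylic acid on this carbon would give a step beyond the scatter stays open. So does whether any change elsewhere on the shared core would.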